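A few compounds are considered here, and "the series" means these few. Any claim that something is new, unique, unknown or untested is made for them only; others in the source may bear on it.

Measured compounds:
compound 1 `Cc1ccc(NC(=O)NC(=O)c2ccc(OCc3ccccc3F)cc2)cc1-c1nc2ccccc2[nH]1` — 4110 nM
compound 2 `Cc1ccc(COc2ccc(C(=O)NC(=O)Nc3ccc(C)c(-c4nc5ccccc5[nH]4)c3)cc2)cc1` — 26000 nM
compound 3 `Cc1ccc(NC(=O)NC(=O)c2ccc(OCc3cccc(F)c3)cc2)cc1-c1nc2ccccc2[nH]1` — 39600 nM

In a functional assay on SW-620 cells (Homo sapiens) for inhibition, read by MTT assay, with a stated time of 48 h (a lower number here means a stronger inhibitor, a higher number a weaker inhibitor), compound 3 gives the highest of the three numbers: its nearest neighbour is compound 2, at a 1.5-fold higher number from compound 2 to compound 3 (0.18 log units; within the scatter), and its furthest is compound 1, at a 9.6-fold higher number from compound 1 to compound 3 (0.98 log units; beyond the scatter). Compound 4 `Cc1ccc(NC(=O)NC(=O)c2ccc(OCc3ccccc3Cl)cc2)cc1-c1nc2ccccc2[nH]1` differs from compound 3 in one place: 2-chlorophenyl in place of 3-fluorophenyl on a saturated chain carbon bound to an oxygen on an aromatic ring. Within the data shown here, no measured step covers this exact exchange. The step of a 9.6-fold higher number from compound 1 to compound 3 (0.98 log units; beyond the scatter) bears on it most closely, since compound 4 returns the halogen to the 2-position that compound 1 carries; read backwards it points to a lower number. Going by these compounds, whether chlorine in place of fluorine shifts this further is unknown. Compound 4 is therefore expected to fall well below compound 3, at about 7000 nM (range 2000 nM to 30000 nM), a step of a 5.7-fold lower number from compound 3 to compound 4 (0.75 log units; beyond the scatter).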

Compound 4, half-maximal inhibitory concentration: 35700 nM
Beside the measured number, compound 4's estimate is 5.1-fold (0.71 log units) below it; the whole stated range lies below it.
By their numbers in this assay, from the lowest: compound 1; then compounds 2, 4 and 3 (each within the scatter of the next).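

In this assay the 2-chlorophenyl group does not bring back the low number of the 2-fluorophenyl group, with chloro in place of fluoro on an aromatic carbon giving an 8.7-fold higher number from compound 1 to compound 4 (0.94 log units; beyond the scatter), a step beyond the scatter. The other two steps, a 1.1-fold lower number from compound 3 to compound 4 (0.05 log units; within the scatter) and a 1.4-fold higher number from compound 2 to compound 4 (0.14 log units; within the scatter), lie within the scatter, so 2-chlorophenyl, 3-fluorophenyl and 4-methylphenyl cannot be told apart on this carbon. Among these four compounds, only the 2-fluorophenyl group stands apart, and no measurement shown accounts for this. Going by these compounds, it remains open whether an unsubstituted phenyl or a 2-methylphenyl group here would stand with compound 1 or with the other three.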